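The source may hold more compounds than are shown below. What is called first, only, known or untested is meant among the compounds shown, and "the series" means these compounds.

Compound 1 `Nc1ncnn2c([C@@H]3O[C@H](CO)[C@@H](O)[C@H]3O)cc(C#Cc3ccc(F)cc3)c12` carries a 2-(4-fluorophenyl)ethynyl group on the shared core. In a functional assay on CAPAN-1 cells (Homo sapiens) for antiproliferative activity, with a stated time of 72 h (on this read-out higher numbers stand for weaker inhibition and lower numbers for stronger inhibition), compound 1 gives 55400 nM, the lowest of the three numbers seen, though both gaps to it lie within the scatter: compound 2 `Nc1ncnn2c([C@@H]3O[C@H](CO)[C@@H](O)[C@H]3O)cc(-c3ccc(F)cc3)c12` gives 65600 nM and compound 3 `Cc1ccccc1-c1cc([C@@H]2O[C@H](CO)[C@@H](O)[C@H]2O)n2ncnc(N)c12` gives 97500 nM. Compound 4 `Nc1ncnn2c([C@@H]3O[C@H](CO)[C@@H](O)[C@H]3O)cc(-c3ccsc3)c12` is unmeasured; it differs from compound 1 by thiophen-3-yl in place of 2-(4-fluorophenyl)ethynyl on an aromatic carbon. Two measured steps likewise exchange the 2-(4-fluorophenyl)ethynyl group for a single aromatic ring: a 1.2-fold higher number from compound 1 to compound 2 (0.07 log units; within the scatter) and a 1.8-fold higher number from compound 1 to compound 3 (0.25 log units; within the scatter). Both stayed within the scatter, so the expected step of a 1.3-fold higher number from compound 1 to compound 4 (0.10 log units; within the scatter) is at most a slight rise in the number, nothing beyond the scatter. Compound 4 is accordingly estimated at 70000 nM, with a range from 30000 nM to 160000 nM.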

Compound 4, half-maximal inhibitory concentration: 56200 nM
For compound 4 the middle estimate is 1.2-fold (0.10 log units) above the measured one; measured number inside the range.
By their numbers in this assay, from the lowest: compounds 1, 4, 2 and 3 (each within the scatter of the next).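

At this position, a five-membered aromatic ring with one sulfur atom can replace the larger 2-(4-fluorophenyl)ethynyl group, with its triple bond, without a difference beyond the scatter: a 1.0-fold higher number from compound 1 to compound 4 (0.01 log units; within the scatter). The comparisons with the two six-membered aromatic rings agree, with a 1.2-fold lower number from compound 2 to compound 4 (0.07 log units; within the scatter) and a 1.7-fold lower number from compound 3 to compound 4 (0.24 log units; within the scatter), so these four groups cannot be told apart on this read-out. Nothing available here explains why they read alike. From the compounds shown here alone, all four groups contain an aromatic ring, so it remains open whether an amine or a carboxylic acid at this position would give a clearly different number.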